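The source may report more compounds than this note shows. Statements on the series, on what has been measured and on what is new or still open speak of the compounds shown alone.

Compound 1 `O=C(NNC(=S)Nc1ccc([N+](=O)[O-])cc1)c1ccncc1` has been tested in an ADME assay on MCF-10A cells (Homo sapiens) for cytotoxicity, read by WST assay, with a stated time of 48 h; a lower number here means a stronger inhibitor, a higher number a weaker inhibitor. Compound 1 there gives > 300000 nM, which is a limit of the assay rather than a number. Compound 2 `O=C(NNC(=S)Nc1cccc(Cl)c1)c1ccncc1` gives > 300000 nM in this assay, again a limit. Compound 3 `Cc1cccc(C)c1NC(=S)NNC(=O)c1ccncc1` gives > 300000 nM in this assay, also a limit. Taken together, (the limit of > 300000 nM in this assay, at which 3 of the 3 values shown sit), so no compound shows a measurable effect on these cells. Compound 4 `O=C(NNC(=S)Nc1ccc(I)cc1)c1ccncc1` differs from compound 1 by iodo in place of nitro on an aromatic carbon. Within the data shown here, no step between measured compounds is available, so no direction can be read. The step from compound 1 to compound 4 is expected to be a number no higher from compound 1 to compound 4 (the limit leaves the size open), nothing beyond the scatter. Compound 4 is therefore expected to give 300000 nM, within 100000 nM to 300000 nM.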

Compound 4, half-maximal inhibitory concentration: > 300000 nM
Compound 4 gave a limit, no number; the forecaster's own chance of this, stated with the estimate: 85%; the middle value lies on the limit itself.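

Compound 1 and compound 4 each give only a limit, and no new step can be read between them. Still open, on these data alone, is whether changing the group on the aromatic ring alters the result in this assay at all.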